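The source may hold more compounds than are shown below. What is called first, only, known or untested is meant among the compounds shown, and "the series" means these compounds.

Measured so far:
- Compound 1 `Fc1ccc(Nc2nc(-c3cccc(F)c3)nc3ccc(F)cc23)cc1`: > 50000 nM (a limit)
- Compound 2 `Fc1cccc(Nc2nc(-c3cccc(F)c3)nc3ccc(F)cc23)c1`: 48700 nM
- Compound 3 `Oc1ccc(Nc2nc(-c3cccc(F)c3)nc3ccc(F)cc23)cc1`: > 50000 nM (a limit)

In a functional assay on MCF7 cells (Homo sapiens) for cytotoxicity, read by MTT assay, with a stated time of 48 h (a higher number here means a weaker inhibitor, a lower number a stronger inhibitor), compound 3 gives > 50000 nM, which is a limit and not a number. Its exact position is therefore unknown. Compound 4 `Cc1ccccc1Nc1nc(-c2cccc(F)c2)nc2ccc(F)cc12` carries 2-methylphenyl in place of 4-hydroxyphenyl on a nitrogen on an aromatic ring.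

The measured steps that bear on this change all alter the group on that same nitrogen. One change of that group gave an at least 1.0-fold lower number from compound 1 to compound 2 (0.01 log units; that floor lies within the scatter). A second gave an at least 1.0-fold higher number from compound 2 to compound 3 (0.01 log units; that floor lies within the scatter). The third gave a step that the two limits leave unreadable from compound 1 to compound 3. The values themselves sit close together: the limit of > 50000 nM in this assay, at which 2 of the 3 values shown sit. Among the compounds with values here, compound 2 gives 48700 nM, the only exact number so far.

Within the data shown here, no measured compound carries 2-methylphenyl, so this group is untested. With no readable step beyond the scatter among compounds 1, 2 and 3, no step beyond the scatter is expected in this assay. The expected change is an at least 1.1-fold lower number from compound 3 to compound 4 (0.04 log units; that floor lies within the scatter). For compound 4 the estimated value is 45000 nM. The estimated range for compound 4 runs from 15000 nM to 100000 nM, and a reading that gives only a limit would be no surprise.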

Compound 4, half-maximal inhibitory concentration: > 50000 nM
Compound 4: a limit, no number; the forecaster's own chance of this, stated with the estimate: 55%; middle value at least 1.1-fold (0.04 log units) from the limit.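

In this assay compound 4 gives > 50000 nM, which is a limit of the assay and not a number. On this nitrogen, a carbon-only 2-methylphenyl group with no hydrogen-bond donor or acceptor therefore ends at the same limit as 4-hydroxyphenyl, which has one of each, so this swap adds no readable change. The one step that can be read is an at least 1.0-fold higher number from compound 2 to compound 4 (0.01 log units; that floor lies within the scatter), the steps from compound 1 and compound 3 to compound 4 cannot be read, and across all four compounds no step on this nitrogen is shown beyond the scatter, with the values gathered at one end of the scale: the limit of > 50000 nM in this assay, at which 3 of the 4 values shown sit.

From the compounds shown here alone, how far compound 1, compound 3 and compound 4 actually lie from one another remains unknown. Also open, going by these compounds, is whether a different kind of group on this nitrogen, such as a benzyl group, a chain ending in an amine, or a phenyl ring carrying a carboxylic acid, would give a value clearly away from this limit.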